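Swapping chloro for methoxy on a weakly active hydrazone

The compounds below may be only part of what the source reports. "The series", "measured", "known", "first", "only" and "open" are said of these compounds alone.

Measured compounds:
compound 1, `CCOC(=O)N1CCC(=NNC(=O)c2ccc(C(F)(F)F)cc2)CC1`, 37100000 nM
compound 2, `CCOC(=O)N1CCC(=NNC(=O)c2ccc([N+](=O)[O-])cc2[N+](=O)[O-])CC1`, 27300000 nM
compound 3, `O=C(NN=C1CC(c2ccccc2)NC(c2ccccc2)C1)c1ccc(Cl)cc1`, > 400000 nM

In a functional assay on A549 cells (Homo sapiens) for cytotoxicity, read by MTT assay, with a stated time of 24 h (on this read-out higher numbers stand for weaker inhibition and lower numbers for stronger inhibition), compound 3 reaches only a limit, > 400000 nM, so no exact number exists for it. That limit is the limit of > 400000 nM in this assay, at which 1 of the 3 values shown sits. Compound 1 and compound 2 each give a number in this assay, but they share no single point of difference with compound 3, so no step can be read between them.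

Compound 4 is `COc1ccc(C(=O)NN=C2CC(c3ccccc3)NC(c3ccccc3)C2)cc1`. It differs from compound 3 by methoxy in place of chloro on an aromatic carbon. Among the measured compounds shown here, no measured pair shows what this change does in this assay, so the expected step is a step that the limit leaves unreadable from compound 3 to compound 4, a shift no larger than the usual scatter, in no set direction. Compound 4 is therefore expected near 600000 nM, within 150000 nM to 3000000 nM, and most likely again only a limit.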

Compound 4, half-maximal inhibitory concentration: > 400000 nM
Compound 4 gave a limit, no number; the forecaster's own chance of this, stated with the estimate: 70%; the middle value does not contradict the limit.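

No step can be read from compound 3 to compound 4, as both reach only a limit and neither gives a number: the limit of > 400000 nM in this assay, at which 2 of the 4 values shown sit.

The compounds shown leave open whether methoxy in place of chloro shifts the value at all, and in which direction.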